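The source may hold more compounds than are shown below. What is called first, only, known or untested is meant among the compounds shown, and "the series" means these compounds.

In a functional assay on MOLT-4 cells (Homo sapiens) for inhibition (on this read-out lower numbers stand for stronger inhibition and higher numbers for weaker inhibition), compound 1 `O=C1CCCCC/C1=C\c1ccc(F)cc1` gives 250000 nM, compound 2 `O=C1CCCCC/C1=C\c1ccc(Cl)cc1` gives 52600 nM, and compound 3 `O=C1CCCCC/C1=C\c1ccc(Br)cc1` gives 49400 nM. Compound 3 thus sits with compound 2 at the low end of the three numbers. Bromo in place of chloro gives a 1.1-fold lower number from compound 2 to compound 3 (0.03 log units; within the scatter), while replacing fluoro gives larger, modest steps: a 4.8-fold lower number from compound 1 to compound 2 (0.68 log units; beyond the scatter) and a 5.1-fold lower number from compound 1 to compound 3 (0.70 log units; beyond the scatter). Compound 4 `Cc1ccc(/C=C2\CCCCCC2=O)cc1` carries methyl in place of bromo on an aromatic carbon. Among the measured compounds shown here, no measured step involves methyl, so these steps bear on it only indirectly. No change beyond the scatter is expected, with a slight lean toward a higher number. The expected step is a 1.4-fold higher number from compound 3 to compound 4 (0.15 log units; within the scatter). For compound 4 the estimated value is 70000 nM, with an expected range from 30000 nM to 180000 nM.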

Compound 4, half-maximal inhibitory concentration: > 500000 nM
Compound 4 was reported as a limit; the forecaster's own chance of this, stated with the estimate: 10%; middle value at least 7.1-fold (0.85 log units) from the limit.
By their numbers in this assay, from the lowest: compounds 3 and 2 (each within the scatter of the next); then compound 1. At a limit, above all of these: compound 4.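

Compound 4 is reported only as a limit: the limit of > 500000 nM in this assay, at which 1 of the 4 values shown sits. So at this position methyl does not match the two heavier halogens, with an at least 10-fold higher number from compound 3 to compound 4 (1.00 log units; beyond the scatter) and an at least 9.5-fold higher number from compound 2 to compound 4 (0.97 log units; beyond the scatter), whereas the earlier compounds showed only that chloro and bromo could not be told apart. Against fluoro the result is an at least 2.0-fold higher number from compound 1 to compound 4 (0.30 log units; that floor lies within the scatter), so whether methyl truly differs from fluoro stays unsettled.

As far as these compounds go, how far compound 4 lies past its limit remains open. So does whether methoxy, trifluoromethyl or an amine at this position would fall with bromo or with methyl.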